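Swapping cyclopentyl for 4,4-difluorocyclohexyl in compound 2

The compounds below may be only part of what the source reports. "The series", "measured", "known", "first", "only" and "open" are said of these compounds alone.

Within the data shown here, only two compounds on this shared core have been measured so far. In a physicochemical assay for solubility, using the shake flask method, in simulated intestinal fluid, measured as kinetic solubility, with a stated time of 20 h, at pH 6.5 (a lower number here means a less soluble compound, a higher number a more soluble compound), compound 1 (`O=C(O)c1ccnc(Nc2cc3[nH]c(-c4cccc(C(F)(F)F)c4)nc3cn2)c1`) gives 60000 nM, and compound 2 (`FC(F)(F)c1ccc(Nc2cc3[nH]c(C4CCCC4)nc3cn2)nc1`) gives 85000 nM. These two numbers lie within the usual scatter of each other, so compound 2 stands level with compound 1 and neither can be ranked over the other.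

The next compound, compound 3 (`FC1(F)CCC(c2nc3cnc(Nc4ccc(C(F)(F)F)cn4)cc3[nH]2)CC1`), has 4,4-difluorocyclohexyl in place of cyclopentyl on an aromatic carbon, the carbon between two ring nitrogen atoms of the five-membered aromatic ring. The change is 4,4-difluorocyclohexyl in place of cyclopentyl on an aromatic carbon.

Among the measured compounds shown here, no measured step from a single change is available to serve as a guide, so the forecast is a cautious one. In this assay, a modest fall is expected, of a size close to the edge of the scatter, with the reading of 85000 nM for compound 2 as the only anchor. The expected step is a 2.1-fold lower number from compound 2 to compound 3 (0.33 log units; beyond the scatter). The estimate for compound 3 is 40000 nM, within an expected range of 12000 nM to 90000 nM.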

Compound 3, solubility: 93000 nM
The estimate for compound 3 lay 2.3-fold (0.37 log units) below the measured number, and the stated range ends below it.
By their numbers in this assay, from the lowest: compounds 1, 2 and 3 (each within the scatter of the next).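

In this assay the swap gives a 1.1-fold higher number from compound 2 to compound 3 (0.04 log units; within the scatter) and so leaves compound 2 and compound 3 level with each other. Among these compounds, this is the first comparison on the shared core that differs in one place only, and it shows that on the aromatic carbon between two ring nitrogen atoms, 4,4-difluorocyclohexyl and cyclopentyl give readings that cannot be told apart, although the entering group has 8 heavy atoms, 2 of them fluorine, and the leaving group has 5 heavy atoms, all carbon. The position therefore accepts a six-membered non-aromatic ring with 2 fluorine atoms in place of a five-membered carbon ring without any measurable departure from the reading of compound 2, though nothing available explains this result.

What the compounds shown leave open is whether this position stays just as level with a group of another kind, such as an amine, a carboxylic acid or a morpholine ring. Among the compounds shown here, it also remains open whether the same swap would read alike on a core carrying a different group on the ring nitrogen-linked amine side, such as the one in compound 1.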